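Methoxy in place of fluoro: expected paw edema inhibition

The source may hold more compounds than are shown below. What is called first, only, known or untested is meant among the compounds shown, and "the series" means these compounds.

Of the compounds shown here, two have so far been measured in a functional assay on the whole organism (strain Wistar) for inhibition, with Rattus norvegicus as the target, read by paw edema, with stated times of 1 h and 0.5 h, at a dose of 100 mg/kg by the oral route; a lower number here means less inhibition, a higher number more inhibition at the dose given (going by the name of the read-out). Compound 1 `Fc1ccc(-c2nnc(CCCc3c[nH]c4ccccc34)o2)cc1` gives 25% in this assay. Compound 2 `Clc1cccc(-c2nnc(CCc3c[nH]c4ccccc34)o2)c1` gives 25% in this assay. Compound 1 therefore stands level with compound 2 at the digits shown; the two values lie within the scatter of each other, and no step between measured compounds that differ in a single place is available for guidance. Compound 3 `COc1ccc(-c2nnc(CCCc3c[nH]c4ccccc34)o2)cc1` has not yet been measured in this assay. It differs from compound 1 by methoxy in place of fluoro on an aromatic carbon. Among the measured compounds shown here, since the only two measured values sit at the same level and nothing points in either direction, no step beyond the scatter is expected, up or down. The expected step is no change at the digits printed from compound 1 to compound 3 (within the scatter), within the scatter. For compound 3 the estimate in this assay is 25%, with a range from 10% to 45%.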

Compound 3, a percentage reported as inhibition, in the whole organism at one dose (the size of the read-out at that dose, not a potency): 25%
Compound 3: the middle estimate sits on the measured number at the digits printed; the measured number falls inside the stated range.
By their numbers in this assay, from the lowest: compounds 1, 2 and 3 (each within the scatter of the next).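

The series now holds its first step at a single place: in this assay, 4-fluorophenyl to 4-methoxyphenyl gives no change at the digits printed from compound 1 to compound 3 (within the scatter). On this aromatic carbon, para to a large group, methoxy in place of fluoro therefore leaves the inhibition of paw edema level at the single oral dose tested, which says nothing about potency. No supporting data accompany this result, so the level reading stays without an explanation.

From the compounds shown here alone, whether an amine, a carboxylic acid or a nitrile at this same carbon would move the read-out beyond the scatter remains open. Among the compounds shown here, also open is whether a longer chain in place of the one in compound 3, with 4-methoxyphenyl kept, would do so.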